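This account rests on a few compounds, and the source may have more. Where it says the series, first, only, none or still open, it means among the compounds named here.

In a functional assay (Nicotiana tabacum) (on this read-out higher numbers stand for weaker inhibition and lower numbers for stronger inhibition), compound 1 (`CSc1nc(NC2CCCC2)c2cccnc2n1`) gives 490 nM and compound 2 (`COCCNc1nc(SC)nc2ncccc12`) gives 2530 nM, the higher of the two numbers and so the weaker inhibition. Compound 3 (`CCOCCNc1nc(SC)nc2ncccc12`) differs from compound 2 on the side chain: methyl in place of hydrogen on a saturated chain carbon bound to an oxygen on a saturated carbon, which turns methoxy to ethoxy. Going by the values given here, no measured step covers this exact change. The only one that bears on it is a 5.2-fold higher number from compound 1 to compound 2 (0.71 log units; beyond the scatter), with 2-methoxyethyl in place of cyclopentyl on a nitrogen on an aromatic ring. That step shows that this chain can move the number, but it replaces a whole group, whereas compound 3 only extends the chain. In this assay, no step beyond the scatter is therefore expected, with at most a slight drift toward lower numbers. The expected move is a 1.3-fold lower number from compound 2 to compound 3 (0.12 log units; within the scatter). Compound 3 is estimated at 1900 nM, with an expected range of 800 nM to 4500 nM.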

Compound 3, half-maximal inhibitory concentration: 7590 nM
For compound 3 the middle estimate is 4.0-fold (0.60 log units) below the measured one, outside the stated range (above it).
By their numbers in this assay, from the lowest: compound 1; then compound 2; then compound 3.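

In this assay, the end of the side chain proves sensitive: turning methoxy to ethoxy, with methyl in place of hydrogen on a saturated chain carbon bound to an oxygen on a saturated carbon, gives a 3.0-fold higher number from compound 2 to compound 3 (0.48 log units; beyond the scatter), so even this small change moves the number beyond the scatter. Measured against cyclopentyl, the ethoxy chain gives a 15-fold higher number from compound 1 to compound 3 (1.19 log units; beyond the scatter), a larger step than a 5.2-fold higher number from compound 1 to compound 2 (0.71 log units; beyond the scatter) seen with 2-methoxyethyl, so among these compounds both ether chains give weaker inhibition than cyclopentyl, and ethoxy gives the weakest. Nothing available explains why the added methyl has this effect.

The compounds shown leave open whether a longer chain such as propoxy would raise the number further. They also leave open whether a chain ending in hydroxyl or an amine, or a plain butyl chain without the oxygen, would come closer to cyclopentyl.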